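This account rests on a few compounds, and the source may have more. Where it says the series, first, only, none or still open, it means among the compounds named here.

Measured compounds:
- compound 1 `Cc1cc(S(=O)(=O)/N=C(\N)n2nccc2-c2ccccc2)c(SCc2cccc(Cl)c2)cc1Cl`: 88000 nM
- compound 2 `Cc1cc(-c2ccccc2)n(/C(N)=N/S(=O)(=O)c2cc(C)c(Cl)cc2SCc2cccc(Cl)c2)n1`: 25000 nM

Of the compounds shown here, two have been measured in a functional assay on MCF7 cells (Homo sapiens) for cytotoxicity, read by MTT assay, with a stated time of 72 h; on this read-out lower numbers stand for stronger inhibition and higher numbers for weaker inhibition. Compound 1 gives 88000 nM in this assay, the highest of the two numbers. For the measured compounds named here, its nearest neighbour is compound 2, which in this assay gives 25000 nM; the single change between them, a methyl in place of hydrogen on an aromatic carbon, moves the number by a 3.5-fold lower number from compound 1 to compound 2 (0.55 log units; beyond the scatter).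

Compound 3 `Cc1cc(S(=O)(=O)/N=C(\N)n2nccc2-c2ccccc2)c(SCc2cccc3ccccc23)cc1Cl` has not yet been measured. It differs from compound 1 in one place: naphthalen-1-yl in place of 3-chlorophenyl on a saturated chain carbon bound to a sulfur. Going by the values given here, no measured step touches this part of the molecule; the only step on record concerns a methyl on the shared core, a change of a different kind at a different place. The step from compound 1 to compound 2 shows that a small change can shift the number beyond the scatter, but it offers no direction for the present change. Compound 3 is therefore expected to stay close to compound 1, with the step from compound 1 to compound 3 estimated at a 1.3-fold lower number from compound 1 to compound 3 (0.10 log units; within the scatter). Compound 3 is expected to give about 70000 nM in this assay, estimated to fall between 25000 nM and 200000 nM.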

Compound 3, half-maximal inhibitory concentration: 58000 nM
The estimate for compound 3 lay 1.2-fold (0.08 log units) above the measured number; low and high end bracket the measured number.
By their numbers in this assay, from the lowest: compound 2; then compounds 3 and 1 (each within the scatter of the next).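

In this assay, for the compounds shown here, putting naphthalen-1-yl in place of 3-chlorophenyl on a saturated chain carbon bound to a sulfur gives a 1.5-fold lower number from compound 1 to compound 3 (0.18 log units; within the scatter), and this is the only measured step at this place. The earlier compounds shown here spoke only of a methyl on the shared core, whereas this pair shows that a group with 2 six-membered aromatic rings of carbon only and no chlorine reads the same, within the scatter, as a group with one such ring and a chlorine. Nothing measured on these compounds accounts for the two groups reading alike.

This single step swaps the chlorine and the ring count at once, so the two parts of the change cannot be told apart, and plain phenyl at this place would be needed to separate them. The compounds shown also leave open how this place answers to groups of another kind, such as an amine, a carboxylic acid or a longer chain, and whether the methyl that separates compound 2 from compound 1 would do the same alongside naphthalen-1-yl.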